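This account rests on a few compounds, and the source may have more. Where it says the series, first, only, none or still open, it means among the compounds named here.

In an assay on isolated protein for inhibition of Aromatase (Homo sapiens), read by fluorescence and colorimetric assay, with a stated time of 30 min (on this read-out lower numbers stand for stronger inhibition and higher numbers for weaker inhibition), compound 1, whose structure is `c1ccc(C(c2ccccc2)n2ccnn2)cc1`, gives 4580 nM. Among the three compounds measured so far, compound 1 stands at the lowest number, and both steps away from it lie beyond the scatter. Compound 2, `Clc1ccc(OCc2cn(C(c3ccccc3)c3ccccc3)nn2)cc1`, gives 13400 nM in this assay, and compound 3, `O=[N+]([O-])c1ccc(OCc2cn(C(c3ccccc3)c3ccccc3)nn2)cc1`, gives 11600 nM. The step of a 2.9-fold higher number from compound 1 to compound 2 (0.47 log units; beyond the scatter) shows what happens when a (4-chlorophenoxy)methyl group enters on the aromatic carbon of the shared core, while the step of a 1.2-fold lower number from compound 2 to compound 3 (0.06 log units; within the scatter) shows that swapping chloro for nitro on that appended ring changes little.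

Compound 4, `Cc1ccc(OCc2cn(C(c3ccccc3)c3ccccc3)nn2)cc1`, is the next member of this set and has not yet been measured. It differs from compound 1 as follows: (4-methylphenoxy)methyl in place of hydrogen on an aromatic carbon. The step from compound 1 to compound 2 bears most directly on this change, since it is the same kind of group entering at the same place, and the step from compound 2 to compound 3 suggests that the group on the outer ring matters little. Compound 4 is therefore expected to show a modest weakening, about a 2.6-fold higher number from compound 1 to compound 4 (0.42 log units; beyond the scatter), giving an estimated 12000 nM in this assay with a likely range from 6000 nM to 25000 nM.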

Compound 4, half-maximal inhibitory concentration: 26800 nM
Compound 4: middle estimate off by 2.2-fold (0.35 log units), on the low side, outside the stated range (above it).
By their numbers in this assay, from the lowest: compound 1; then compounds 3, 2 and 4 (each within the scatter of the next, the first and the last beyond it).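

Compound 4 gives a second step of the same kind at this aromatic carbon: a 5.9-fold higher number from compound 1 to compound 4 (0.77 log units; beyond the scatter) with a (4-methylphenoxy)methyl group, set beside a 2.9-fold higher number from compound 1 to compound 2 (0.47 log units; beyond the scatter) with the (4-chlorophenoxy)methyl group, so in this assay both of these listed entries of a substituted phenoxymethyl group go with weaker inhibition than the hydrogen of compound 1. The group on the outer ring can no longer be treated as simply indifferent, since the change of methyl in place of nitro gives a 2.3-fold higher number from compound 3 to compound 4 (0.36 log units; beyond the scatter) and lies beyond the scatter, while the change of methyl in place of chloro gives a 2.0-fold higher number from compound 2 to compound 4 (0.30 log units; within the scatter) and stays within it, leaving compound 2 and compound 4 not separated. No measurement is at hand that would explain why the methyl compound parts from the nitro compound but not from the chloro compound.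

The compounds shown carry only chloro, nitro and methyl on the outer ring, so it stays open how an amine, a carboxylic acid or a longer chain at that place would read in this assay. From the compounds shown here alone, it also stays open whether any group on this aromatic carbon could bring the number below that of compound 1.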